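Demethylation of the Aryl Ether in a Pyrazole Urea Series

The source may report more compounds than this note shows. Statements on the series, on what has been measured and on what is new or still open speak of the compounds shown alone.

The measured compounds and their numbers in a functional assay on COLO 205 cells (Homo sapiens) for inhibition, read by sulforhodamine B assay, with a stated time of 48 h; on this read-out lower numbers stand for stronger inhibition of growth and higher numbers for weaker inhibition of growth:
compound 1 `O=C(Nc1cccc(-n2cc(-c3ccncc3)c(-c3ccc(Cl)c(O)c3)n2)c1)Nc1cccc(C(F)(F)F)c1`, compound 1 gives 23800 nM;
compound 2 `O=C(Nc1cccc(-n2cc(-c3ccncc3)c(-c3ccc(Cl)c(O)c3)n2)c1)Nc1ccc(Cl)c(Cl)c1`, compound 2 gives 9490 nM;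
compound 3 `COc1cc(-c2nn(-c3cccc(NC(=O)Nc4ccc(Cl)c(C(F)(F)F)c4)c3)cc2-c2ccncc2)ccc1Cl`, compound 3 gives 1540 nM.

Compound 3 stands lowest of the three numbers in this assay, with compound 2 nearest and compound 1 furthest. Among the measured compounds shown here, the one step between measured compounds that differ in a single place, a 2.5-fold lower number from compound 1 to compound 2 (0.40 log units; beyond the scatter), concerns the aryl group on the urea and does not touch the position altered here.

Compound 4 `O=C(Nc1cccc(-n2cc(-c3ccncc3)c(-c3ccc(Cl)c(O)c3)n2)c1)Nc1ccc(Cl)c(C(F)(F)F)c1` keeps the urea aryl of compound 3 and differs only by hydrogen in place of methyl on an oxygen on an aromatic ring. For the measured compounds named here, no measured pair shows this change on its own; compounds 1 and 2 carry the hydroxy group but also a different urea aryl, so their numbers cannot be read as a measure of it. The step is therefore expected to be small and of uncertain direction, with a broad range. Compound 4 is estimated at 3000 nM, between 800 nM and 12000 nM, a step of a 1.9-fold higher number from compound 3 to compound 4 (0.29 log units; within the scatter) from compound 3.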

Compound 4, concentration for total growth inhibition: 6750 nM
For compound 4 the middle estimate is 2.3-fold (0.35 log units) below the measured one; low and high end bracket the measured number.
By their numbers in this assay, from the lowest: compound 3; then compounds 4 and 2 (each within the scatter of the next); then compound 1.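

With the urea aryl held fixed, the change from methoxy to hydroxy can now be read on its own in this assay as a 4.4-fold higher number from compound 3 to compound 4 (0.64 log units; beyond the scatter) and the methoxy compound keeps the stronger inhibition of growth in this pair. Among the hydroxy compounds, chloro in place of hydrogen on an aromatic carbon gives a 3.5-fold lower number from compound 1 to compound 4 (0.55 log units; beyond the scatter) while trifluoromethyl in place of chloro gives a 1.4-fold lower number from compound 2 to compound 4 (0.15 log units; within the scatter) and so does not separate those two urea aryl groups. Compound 4 thus shows that the low number of compound 3 depends in part on the methoxy group and not on the urea aryl alone.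

Going by these compounds, a single pair carries this change, so whether it holds with other urea aryl groups stays open, as does what an ethoxy group or an amine would give in place of the methoxy. Nothing given here explains the step.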